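The source may report more compounds than this note shows. Statements on the series, on what has been measured and on what is new or still open speak of the compounds shown alone.

The compounds here share one core and differ in the group on an amide-type nitrogen. Compound 1 `COc1cccc(OC)c1C(=O)Nc1c[nH]nc1C(=O)NN1CCOCC1` carries morpholin-4-yl there, compound 2 `COc1cccc(OC)c1C(=O)Nc1c[nH]nc1C(=O)NCc1ccccc1` carries benzyl, and compound 3 `COc1cccc(OC)c1C(=O)Nc1c[nH]nc1C(=O)Nc1ccccc1` carries phenyl. In an ADME assay on MRC5 cells (Homo sapiens) for inhibition, with a stated time of 72 h (a lower number here means that less compound is needed, a higher number that more compound is needed for the effect), compound 1 gives > 50000 nM, which is a limit of the assay. Compound 2 gives 50000 nM. Compound 3 gives > 50000 nM, which is also a limit. Compound 3 therefore stands at the limit of > 50000 nM in this assay, at which 2 of the 3 values shown sit, with no exact number to place it.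

Compound 4 `COc1cccc(OC)c1C(=O)Nc1c[nH]nc1C(=O)NC1CCC(C)CC1` makes one change to compound 3: 4-methylcyclohexyl in place of phenyl on an amide-type nitrogen. In words, 4-methylcyclohexyl takes the place of phenyl on the amide-type nitrogen.

Three measured steps change this same nitrogen: a number no higher from compound 1 to compound 2 (the limit leaves the size open), a step that the two limits leave unreadable from compound 1 to compound 3 and a number no lower from compound 2 to compound 3 (the limit leaves the size open). None of them has a readable size, so they show no clear move in either direction. Going by the values given here, the only true number among them is the one for compound 2, at 50000 nM, and it anchors the expectation. In this assay, among the compounds with values here, no step of clear size or direction is therefore expected, and the estimated step is an at least 1.2-fold lower number from compound 3 to compound 4 (0.09 log units; that floor lies within the scatter). The assay may well report only a limit again. For compound 4, the estimated value is 40000 nM, with an expected range from 15000 nM to 50000 nM.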

Compound 4, half-maximal effective concentration: 45000 nM
For compound 4 the middle estimate is 1.1-fold (0.05 log units) below the measured one; the range from low to high includes it.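

In this assay, the amide-type nitrogen now has a second exact number, so two true values can be compared: a 1.1-fold lower number from compound 2 to compound 4 (0.05 log units; within the scatter). The steps that start from a limit read an at least 1.1-fold lower number from compound 3 to compound 4 (0.04 log units; that floor lies within the scatter) and an at least 1.1-fold lower number from compound 1 to compound 4 (0.04 log units; that floor lies within the scatter), so they too show no move of clear size. The new information is that a non-aromatic ring of carbon, 4-methylcyclohexyl, gives a value close to that of compound 2, and that the values shown crowd at the top of what the assay reports, where a real difference between these groups would be hard to see: the limit of > 50000 nM in this assay, at which 2 of the 4 values shown sit.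

All four groups shown on this nitrogen contain a ring, so it remains open whether any group here can bring the number in this assay clearly down. A group carrying an amine or a carboxylic acid, or a plain longer carbon chain without a ring, would test this position in a way that the present compounds cannot.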